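The source may report more compounds than this note shows. Statements on the series, on what has been measured and on what is new or still open speak of the compounds shown alone.

Compound 3 `CCC(O)c1cn(CCNc2nonc2/C(=N/O)Nc2ccc(F)c(Br)c2)nn1` gives 947 nM in an assay on isolated protein for inhibition of Indoleamine 2,3-dioxygenase 2 (Homo sapiens) (on this read-out higher numbers stand for weaker inhibition and lower numbers for stronger inhibition), which is the second highest of the three numbers measured: compound 1 `OCCc1cn(CCNc2nonc2/C(=N/O)Nc2ccc(F)c(Br)c2)nn1` gives 1170 nM, and compound 2 `CC(O)c1cn(CCNc2nonc2/C(=N/O)Nc2ccc(F)c(Br)c2)nn1` gives 362 nM. The step of a 1.2-fold lower number from compound 1 to compound 3 (0.09 log units; within the scatter) lies within the scatter, whereas a 2.6-fold higher number from compound 2 to compound 3 (0.42 log units; beyond the scatter) goes beyond it. Compound 4 `CCC(C)(O)c1cn(CCNc2nonc2/C(=N/O)Nc2ccc(F)c(Br)c2)nn1` differs from compound 3 by methyl in place of hydrogen on a saturated chain carbon bound to an aromatic carbon, an oxygen on a saturated carbon and a saturated chain carbon. Among the measured compounds shown here, the closest precedent is the added methyl on a chain carbon in a 2.6-fold higher number from compound 2 to compound 3 (0.42 log units; beyond the scatter), a modest weakening; a 3.2-fold lower number from compound 1 to compound 2 (0.51 log units; beyond the scatter) shows that rearranging the hydroxyalkyl chain can also strengthen inhibition. On balance a small weakening or no change beyond the scatter is expected for compound 4, with a 1.5-fold higher number from compound 3 to compound 4 (0.17 log units; within the scatter). Compound 4 is therefore estimated at 1400 nM, ranging from 500 nM to 4000 nM.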

Compound 4, half-maximal inhibitory concentration: 958 nM
Compound 4: the middle estimate sits 1.5-fold (0.16 log units) above what was measured; measured number inside the range.
By their numbers in this assay, from the lowest: compound 2; then compounds 3, 4 and 1 (each within the scatter of the next).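

In this assay, methyl in place of hydrogen on this saturated chain carbon, bound to an aromatic carbon and an oxygen on a saturated carbon, leaves the number within the scatter (a 1.0-fold higher number from compound 3 to compound 4 (0.01 log units; within the scatter)). This differs from the earlier added methyl on the chain carbon two bonds along, which gave a step beyond the scatter. Even the ethyl in place of hydrogen on this carbon leaves compound 4 apart from compound 2 (a 2.6-fold higher number from compound 2 to compound 4 (0.42 log units; beyond the scatter)), while compound 4 stays within the scatter of compound 1 (a 1.2-fold lower number from compound 1 to compound 4 (0.09 log units; within the scatter)). On these data alone, whether an amine in place of the hydroxyl, or a longer chain on this carbon, would keep that number remains open. Nothing available here accounts for these steps.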